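Methoxy for Methyl on the Aryl Ring of Pyrazoline Amides

The source may hold more compounds than are shown below. What is called first, only, known or untested is meant among the compounds shown, and "the series" means these compounds.

Measured so far:
compound 1, `CCC(=O)N1N=C(c2ccc(OC)cc2)CC1c1ccccc1`, 63100 nM in an assay on isolated protein for inhibition of Amine oxidase [flavin-containing] A (Bos taurus); a higher number here means a weaker inhibitor, a lower number a stronger inhibitor
compound 2, `CCC(=O)N1N=C(c2ccc(OC)cc2)CC1c1ccc(C)cc1`, 7240 nM in this assay

Compound 2 gives the lowest number of the two measured in this assay; its nearest neighbour is compound 1, and the step of an 8.7-fold lower number from compound 1 to compound 2 (0.94 log units; beyond the scatter) lies beyond the scatter. Compound 3, `CCC(=O)N1N=C(c2ccc(OC)cc2)CC1c1ccc(OC)cc1`, has not yet been measured. It differs from compound 2 by methoxy in place of methyl on an aromatic carbon, placed on an aromatic carbon para to a large group. Going by the values given here, no measured step swaps methoxy for methyl, so the only related step is an 8.7-fold lower number from compound 1 to compound 2 (0.94 log units; beyond the scatter), which concerns a different exchange and bears on the present one only loosely. With no direct evidence, the expectation is a small change, likely within or near the scatter, and the expected step is a 1.2-fold higher number from compound 2 to compound 3 (0.09 log units; within the scatter). Compound 3 is therefore estimated at 9000 nM, with a range from 3000 nM to 30000 nM.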

Compound 3, half-maximal inhibitory concentration: 1170 nM
For compound 3 the middle estimate is 7.7-fold (0.89 log units) above the measured one, and the stated range ends above it.
By their numbers in this assay, from the lowest: compound 3; then compound 2; then compound 1.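

Replacing methyl with methoxy at this aromatic carbon is not a neutral exchange in this assay: it gives a 6.2-fold lower number from compound 2 to compound 3 (0.79 log units; beyond the scatter), so the position responds to which group sits there and not only to whether a group is present. Set against hydrogen at the same carbon, methoxy gives a 54-fold lower number from compound 1 to compound 3 (1.73 log units; beyond the scatter), a larger step than the one methyl gave, an 8.7-fold lower number from compound 1 to compound 2 (0.94 log units; beyond the scatter). Nothing measured here accounts for the difference between the two groups.

From the compounds shown here alone, whether ethoxy, a hydroxyl group or a chlorine atom at this carbon would lower the number further remains open. So does whether methoxy would bring a similar step at another aromatic carbon, or on a core carrying a longer amide chain.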